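The source may report more compounds than this note shows. Statements on the series, on what has been measured and on what is new or still open speak of the compounds shown alone.

Measured compounds:
- compound 1 `N#Cc1ccc(NC(=S)N/N=C/c2ccc3ccccc3n2)cc1`: 20000 nM
- compound 2 `CC(C)c1cccc(C(C)C)c1NC(=S)N/N=C/c1ccc2ccccc2n1`: 16400 nM

In a functional assay on HeLa cells (Homo sapiens) for antiproliferative activity, read by sulforhodamine B assay, with a stated time of 72 h (a higher number here means a weaker inhibitor, a lower number a stronger inhibitor), compound 1 gives 20000 nM, the highest of the two numbers shown. Its nearest neighbour is compound 2, which in this assay gives 16400 nM; the gap between the two is within the usual scatter, so no order between them can be read. Compound 3 `S=C(N/N=C/c1ccc2ccccc2n1)Nc1ccccc1` has not yet been measured. It differs from compound 1 in one place: hydrogen in place of cyano on an aromatic carbon. Going by the values given here, no step between two measured compounds touches this position, so there is nothing to calibrate the size of the change against. Given that compound 1 and compound 2 both sit at a similar weak level in this assay, the step of no change at the digits printed from compound 1 to compound 3 (within the scatter) is expected to stay within the scatter, in no firm direction. Compound 3 is therefore estimated to give about 20000 nM in this assay, with a range from 7000 nM to 60000 nM.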

Compound 3, half-maximal inhibitory concentration: 27400 nM
Compound 3: middle estimate off by 1.4-fold (0.14 log units), on the low side, within the range that was stated.
By their numbers in this assay, from the lowest: compounds 2, 1 and 3 (each within the scatter of the next).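

Going by these compounds alone, this is the first step that touches the cyano group on this aromatic carbon: in this assay, the change to hydrogen gives a 1.4-fold higher number from compound 1 to compound 3 (0.14 log units; within the scatter). The change from 4-cyanophenyl to phenyl therefore leaves the number at the same weak level, and at this position the cyano group can give way to hydrogen with no difference that can be read from the scatter. Nothing available explains this result.

Going by these compounds, whether an amine, a carboxylic acid or a methoxy group on this same carbon would move the number beyond the scatter stays open. The compounds shown also give no step at any other part of the shared core, so it remains open whether a change elsewhere would shift the number from this weak level.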